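The source may hold more compounds than are shown below. What is called first, only, known or untested is meant among the compounds shown, and "the series" means these compounds.

Compound 1 `COc1cc(/C=C2\Cc3ccccc3/C(=C\c3ccc([N+](=O)[O-])cc3)C2=O)ccc1O` and compound 2 `COc1ccc(/C=C2\Cc3ccccc3/C(=C\c3ccc([N+](=O)[O-])cc3)C2=O)cc1OC` share one core, while compound 3 `O=C1/C(=C/c2ccc(O)cc2)CCC/C1=C\c1ccc([N+](=O)[O-])cc1` and compound 4 `COc1ccc(/C=C2\CCC/C(=C\c3ccc([N+](=O)[O-])cc3)C2=O)cc1` share another; how the two cores differ is not broken down here. In a functional assay on HPC cells (Homo sapiens) for cytotoxicity (on this read-out higher numbers stand for lower toxicity in this test and lower numbers for higher toxicity in this test), compound 1 gives 83000 nM. For compound 2 the assay reports only a limit, > 400000 nM. The change between them is methyl in place of hydrogen on an oxygen on an aromatic ring, and it gives an at least 4.8-fold higher number from compound 1 to compound 2 (0.68 log units; beyond the scatter), a step whose true size is open because of the limit of > 400000 nM in this assay, at which 2 of the 3 values shown sit. For compound 3 the assay likewise reports only a limit, > 400000 nM. Compound 4 carries the same change as compound 2 did: methyl in place of hydrogen on an oxygen on an aromatic ring. Compound 4 is expected to stay at or beyond the limit, with an estimated step that the limit leaves unreadable from compound 3 to compound 4 from a starting point that is itself only a limit, and the expectation rests on compound 3 at > 400000 nM and on compound 2 at > 400000 nM. For compound 4 the estimate in this assay is 500000 nM, between 200000 nM and 2000000 nM.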

Compound 4, half-maximal cytotoxic concentration: > 400000 nM
Compound 4: a limit, no number; the forecaster's own chance of this, stated with the estimate: 85%; the middle value does not contradict the limit.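

Compound 3 and compound 4 both give only a limit in this assay, so the step from hydroxy to methoxy between them cannot be read: the limit of > 400000 nM in this assay, at which 3 of the 4 values shown sit.

The compounds shown leave open whether this change moves the read-out at all on the core of compound 3, and how it compares with the same change on the core of compound 1.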